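The source may report more compounds than this note shows. Statements on the series, on what has been measured and on what is new or still open speak of the compounds shown alone.

Measured compounds:
Compound 1, `COc1cc2c(Oc3ccc(NC(=O)c4cn(-c5ccc(Cl)cc5Cl)cn4)cc3F)ccnc2cc1OCCCN1CCN(C)CC1`, in a functional assay on A549 cells (Homo sapiens) for cytotoxicity, read by MTT assay, with a stated time of 72 h; on this read-out higher numbers stand for weaker inhibition and lower numbers for stronger inhibition: 3850 nM
Compound 2, `COc1cc2c(Oc3ccc(NC(=O)c4cn(-c5ccccc5OC(F)(F)F)cn4)cc3F)ccnc2cc1OCCCN1CCCCC1`, in this assay: 270 nM
Compound 3, `COc1cc2c(Oc3ccc(NC(=O)c4cn(-c5cc(C)ccc5C)cn4)cc3F)ccnc2cc1OCCCN1CCCCC1`, in this assay: 510 nM

Compound 1 has the highest number of the three in this assay; compound 3 is the nearest to it and compound 2 the furthest, and both gaps lie beyond the scatter. Compound 4, `COc1cc2c(Oc3ccc(NC(=O)c4cn(-c5ccc(Cl)cc5Cl)cn4)cc3F)ccnc2cc1OCCCN1CCCCC1`, has not yet been measured. It differs from compound 1 in one place: piperidin-1-yl in place of 4-methylpiperazin-1-yl on a saturated chain carbon, three bonds along the chain from an oxygen on an aromatic ring.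

Among the compounds with values here, no measured pair isolates this change. Within the data shown here, the one recorded step, a 1.9-fold higher number from compound 2 to compound 3 (0.28 log units; within the scatter), concerns the aryl group on the aromatic nitrogen and stays within the scatter, which suggests that the aryl change alone does not account for the gap between compound 1 and compounds 2 and 3. Compounds 2 and 3 both carry the piperidin-1-yl tail and both give numbers well below compound 1, so a move toward their range is expected for compound 4, though the aryl group of compound 4 matches compound 1 and not either of them. Compound 4 is therefore estimated at 700 nM in this assay, within a range of 250 nM to 2500 nM, which would mean an expected step of a 5.5-fold lower number from compound 1 to compound 4 (0.74 log units; beyond the scatter).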

Compound 4, half-maximal inhibitory concentration: 7490 nM
Compound 4: middle estimate off by 11-fold (1.03 log units), on the low side; measured number above the stated range.
By their numbers in this assay, from the lowest: compounds 2 and 3 (each within the scatter of the next); then compounds 1 and 4 (each within the scatter of the next).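

With the aryl group held at 2,4-dichlorophenyl, putting piperidin-1-yl in place of 4-methylpiperazin-1-yl on the saturated chain gives a 1.9-fold higher number from compound 1 to compound 4 (0.29 log units; within the scatter) in this assay and so does not separate the two compounds. With the tail held at piperidin-1-yl, the aryl group on the aromatic nitrogen matters far more: 2,4-dichlorophenyl in place of 2,5-dimethylphenyl gives a 15-fold higher number from compound 3 to compound 4 (1.17 log units; beyond the scatter) and in place of 2-(trifluoromethoxy)phenyl gives a 28-fold higher number from compound 2 to compound 4 (1.44 log units; beyond the scatter) as a second large step. The earlier compounds showed only a 1.9-fold higher number from compound 2 to compound 3 (0.28 log units; within the scatter) at this aryl position, so the new compound is the first to show that a change there can produce a large step, while the tail change shown here does not.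

Still open, on these data alone, is whether the tail change would also stay within the scatter with 2-(trifluoromethoxy)phenyl or 2,5-dimethylphenyl on the aromatic nitrogen, and how a morpholin-4-yl or dimethylamino tail, or a single-chlorine group such as 4-chlorophenyl, would read in this assay. No supporting data are at hand that would explain the large steps seen with 2,4-dichlorophenyl.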